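Trifluoromethyl in Place of Nitro: Cytotoxicity Expected Unchanged

The source may hold more compounds than are shown below. What is called first, only, known or untested is meant among the compounds shown, and "the series" means these compounds.

Three related compounds have so far been tested in an ADME assay on J774.1 cells (Mus musculus) for cytotoxicity, read by MTT assay, with a stated time of 48 h; on this read-out higher numbers stand for weaker inhibition and lower numbers for stronger inhibition. Compound 1, `Cc1c(C(=O)N/N=C/c2ccccn2)no[n+]1[O-]`, gives > 400000 nM, which is a limit of the assay rather than a measured number. Compound 2, `Cc1c(C(=O)N/N=C/c2ccc([N+](=O)[O-])cc2)no[n+]1[O-]`, gives > 300000 nM, again only a limit. Compound 3, `Cc1nc2ccccn2c1C(=O)N/N=C/c1no[n+]([O-])c1C`, gives > 400000 nM, also a limit. Two of the three results sit at the limit of > 400000 nM in this assay, at which 2 of the 3 values shown sit. The result for compound 2 sits at the limit of > 300000 nM in this assay, at which 1 of the 3 values shown sits. Compound 2 thus stands alongside the other two: none of the three shows a measurable effect on these cells within the tested range, and no order among them can be read from the numbers.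

Compound 4, `Cc1c(C(=O)N/N=C/c2ccc(C(F)(F)F)cc2)no[n+]1[O-]`, has not yet been measured. It differs from compound 2 in one place, trifluoromethyl in place of nitro on an aromatic carbon: the nitro leaves and a trifluoromethyl enters on an aromatic carbon of a six-membered aromatic ring of carbon only, para to a large group.

Among the compounds with values here, no two measured compounds differ in a single place, so no measured step exists to lean on. Within the data shown here, with every value so far a limit, the step from compound 2 to compound 4 is expected to be a step that the limit leaves unreadable from compound 2 to compound 4, that is, none beyond the scatter. Compound 4 is therefore estimated to give 400000 nM in this assay, with a range from 150000 nM to 1000000 nM, and most likely again only a limit.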

Compound 4, half-maximal inhibitory concentration: > 400000 nM
Compound 4 ended at the assay's limit; the forecaster's own chance of this, stated with the estimate: 85%; the middle value lies on the limit itself.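

Compound 2 and compound 4 both end at limits in this assay rather than at measured numbers, and the step between them, trifluoromethyl in place of nitro, cannot be read. The compounds shown leave open how strongly any of them acts on these cells, and which change in structure would give a measurable value.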